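A Plainer Aryl Ring on the Amide-Type Nitrogen

This account rests on a few compounds, and the source may have more. Where it says the series, first, only, none or still open, it means among the compounds named here.

Compound 1 `Cc1ccc(NC(=S)OCCNC(=O)C(C)(C)Oc2ccc(Cl)cc2)cc1`: 0.0167 h
Compound 2 `CC(C)(Oc1ccc(Cl)cc1)C(=O)NCCOC(=S)Nc1ccc([N+](=O)[O-])cc1Cl`: 0.0283 h
Compound 3 `NC(=S)c1ccc(OC(=O)c2cccnc2)cc1`: 0.035 h

In an ADME assay for pharmacokinetics, in phosphate buffer, tested at 60 uM (on this read-out lower numbers stand for a shorter-lived compound and higher numbers for a longer-lived compound), compound 2 gives 0.0283 h, a number that sits among the three measured ones without standing apart: the gap to compound 3 and the gap to compound 1 both lie within the usual scatter of repeated measurements, so no ordering among them can be claimed.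

Compound 4 `CC(C)(Oc1ccc(Cl)cc1)C(=O)NCCOC(=S)Nc1ccccc1` differs from compound 2 in one place: phenyl in place of 2-chloro-4-nitrophenyl on an amide-type nitrogen. Within the data shown here, only one measured step touches the same position. That is the step of a 1.7-fold higher number from compound 1 to compound 2 (0.23 log units; within the scatter), where 2-chloro-4-nitrophenyl replaced 4-methylphenyl on the amide-type nitrogen, and it did not reach beyond the scatter. Exchanging the ring once more, this time for plain phenyl, therefore gives no grounds to expect a shift of any clear size in this assay, in either direction.

Compound 4 is accordingly expected to land close to compound 2, with the step of a 1.3-fold lower number from compound 2 to compound 4 (0.11 log units; within the scatter) estimated to stay within the scatter. The estimate for compound 4 in this assay is 0.022 h, with a range from 0.01 h to 0.045 h.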

Compound 4, half-life: 0.0233 h
Compound 4: middle estimate off by 1.1-fold (0.02 log units), on the low side; measured number inside the range.
By their numbers in this assay, from the lowest: compounds 1, 4, 2 and 3 (each within the scatter of the next, the first and the last beyond it).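

Compound 4 shows that the ring on this amide-type nitrogen can lose both the chlorine and the nitro group, going from the 10 heavy atoms of 2-chloro-4-nitrophenyl to the 6 carbons of phenyl, and in this assay the result is still only a 1.2-fold lower number from compound 2 to compound 4 (0.08 log units; within the scatter). Compound 4 also links the two earlier compounds, since hydrogen in place of methyl on an aromatic carbon gives a 1.4-fold higher number from compound 1 to compound 4 (0.14 log units; within the scatter), so all three rings on this nitrogen, 4-methylphenyl, 2-chloro-4-nitrophenyl and phenyl, now stand within the scatter of one another in every pairwise step. Nothing in the information available accounts for this lack of separation.

As far as these compounds go, it remains open whether a phenyl ring carrying an amine or a carboxylic acid, or a butyl chain in place of the ring, would give a half-life that stands clear of the scatter. All of these compounds also keep the thiocarbonyl carbon on this nitrogen, so what a plain carbonyl would do there is an equally open question.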